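A few compounds are considered here, and "the series" means these few. Any claim that something is new, unique, unknown or untested is made for them only; others in the source may bear on it.

Compound 1 `CCOc1ccc(C)c(-c2cccc(COc3ccc(OCC(=O)O)c(F)c3)c2)c1` carries a 5-ethoxy-2-methylphenyl group on its core, and in a functional assay on CHO cells for agonist activity at Free fatty acid receptor 1 (Homo sapiens), read by FLIPR and calcium flux (a lower number here means that less compound is needed, a higher number that more compound is needed for the effect), compound 1 gives 220 nM, the lowest number among the three compounds measured. Compound 2 `Cc1ccc(OCC2CCCCC2)cc1-c1cccc(COc2ccc(OCC(=O)O)c(F)c2)c1` gives 910 nM and compound 3 `Cc1ccc(OCC2CCCC2)cc1-c1cccc(COc2ccc(OCC(=O)O)c(F)c2)c1` gives 490 nM. The measured steps all change the group on the saturated chain carbon bound to the oxygen on the aromatic ring: a 4.1-fold higher number from compound 1 to compound 2 (0.62 log units; beyond the scatter) and a 2.2-fold higher number from compound 1 to compound 3 (0.35 log units; beyond the scatter), while a 1.9-fold lower number from compound 2 to compound 3 (0.27 log units; within the scatter). Larger groups at that point thus gave higher numbers.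

Compound 4 `COc1ccc(-c2cccc(COc3ccc(OCC(=O)O)c(F)c3)c2)cc1` differs from compound 1 in another way: 4-methoxyphenyl in place of 5-ethoxy-2-methylphenyl on an aromatic carbon. Going by the values given here, this removes the methyl and shortens the ethoxy group to methoxy at a different point of the ring, a change that no measured step covers directly. The known steps only show that the number is sensitive to what sits on this ring. Compound 4 is therefore expected to give a somewhat higher number, estimated at 450 nM with a range from 120 nM to 1700 nM, meaning an expected 2.0-fold higher number from compound 1 to compound 4 (0.31 log units; beyond the scatter).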

Compound 4, half-maximal effective concentration: 170 nM
Compound 4: the middle estimate sits 2.6-fold (0.42 log units) above what was measured; low and high end bracket the measured number.
By their numbers in this assay, from the lowest: compounds 4 and 1 (each within the scatter of the next); then compounds 3 and 2 (each within the scatter of the next).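

Moving from the 5-ethoxy-2-methylphenyl group to the smaller 4-methoxyphenyl group gives a 1.3-fold lower number from compound 1 to compound 4 (0.11 log units; within the scatter) in this assay, so this change makes no clear difference to the number. Going by these compounds alone, the earlier compounds showed only that larger groups on the ether oxygen gave higher numbers; this result shows that the aromatic ring can lose its methyl and carry a shorter alkoxy group at a different point while the number stays within the scatter. Nothing available here explains why the number holds.

This single step changes the methyl, the length of the alkoxy group and its place on the ring together, so their separate contributions cannot be told apart. As far as these compounds go, how a 4-ethoxyphenyl group would behave here remains open, as does the result of putting a nitrile or an amine in place of the methoxy group.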